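Removing the hydroxy group from compound 3

This account rests on a few compounds, and the source may have more. Where it says the series, first, only, none or still open, it means among the compounds named here.

Compound 1 `COc1cc(C2CC(c3cccc(O)c3)=NN2C(=O)OCc2ccccc2)cc(OC)c1OC`: > 10000 nM, a limit
Compound 2 `COC(=O)N1N=C(c2ccccc2)CC1c1ccccc1`: > 10000 nM, a limit
Compound 3 `COC(=O)N1N=C(c2ccccc2)CC1c1ccc(OC)c(O)c1`: 4960 nM

For the measured compounds named here, in a functional assay on A2780 cells (Homo sapiens) for antiproliferative activity, read by MTT assay, with a stated time of 48 h (on this read-out lower numbers stand for stronger inhibition of growth and higher numbers for weaker inhibition of growth), compound 3 gives 4960 nM, the only true number in the set. The other two entries are limits, as the limit of > 10000 nM in this assay, at which 2 of the 3 values shown sit, records. Compound 4 `COC(=O)N1N=C(c2ccccc2)CC1c1ccc(OC)cc1` differs from compound 3 by hydrogen in place of hydroxy on an aromatic carbon, ortho to a methoxy group: hydrogen in place of hydroxy on an aromatic carbon. Going by the values given here, no measured pair isolates this change. Compound 2, with neither hydroxy nor methoxy on that ring, stands at > 10000 nM, which is a limit. On that basis, a modest weakening in this assay is expected, the estimated 1.8-fold higher number from compound 3 to compound 4 (0.26 log units; within the scatter), and a reading at the limit would not surprise. For compound 4 the estimate is 9000 nM, with an expected range of 4000 nM to 20000 nM.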

Compound 4, concentration for 50% growth inhibition: > 10000 nM
Compound 4 ended at the assay's limit; the forecaster's own chance of this, stated with the estimate: 55%; middle value at least 1.1-fold (0.04 log units) away from the limit.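

With hydroxy on this aromatic carbon, ortho to a methoxy group, replaced by hydrogen, this assay gives an at least 2.0-fold higher number from compound 3 to compound 4 (0.30 log units; that floor lies within the scatter). Compound 4 is a limit, so only this floor is known, and it does not show a loss beyond the scatter; the step between the two limits, from compound 2 to compound 4, cannot be read. The assay's ceiling restricts what this series can show: the limit of > 10000 nM in this assay, at which 3 of the 4 values shown sit.

From the compounds shown here alone, how far compound 4 lies past that limit stays open. Also open, going by these compounds, is whether an amine or a fluorine at this position would give a true number in this assay.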